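From 4-fluorophenyl to 6-fluoropyridin-3-yl on a shared core

The source may hold more compounds than are shown below. What is called first, only, known or untested is meant among the compounds shown, and "the series" means these compounds.

Measured in a functional assay on CNE-2 cells (Homo sapiens) for antiproliferative activity, read by sulforhodamine B assay, with a stated time of 48 h; on this read-out lower numbers stand for stronger inhibition and higher numbers for weaker inhibition:
- compound 1 `COc1ccc(/C=C/C(=O)c2ccccc2-c2ccc(F)cc2)cc1`: 53 nM
- compound 2 `COc1ccc(/C=C/C(=O)c2ccccc2-c2ccc(F)cc2)cc1OC`: 81 nM
- compound 3 `Cc1ccc(/C=C/C(=O)c2ccccc2-c2ccc(F)cc2)o1`: 14000 nM

Compound 1 sits at the low end of these numbers, the end of strong inhibition, and level with compound 2 within the scatter. Compound 3 lies far away from both.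

Still unmeasured is compound 4 `COc1ccc(/C=C/C(=O)c2ccccc2-c2ccc(F)nc2)cc1`, which carries 6-fluoropyridin-3-yl in place of 4-fluorophenyl on an aromatic carbon, ortho to a large group. The counted difference is 6-fluoropyridin-3-yl in place of 4-fluorophenyl on an aromatic carbon.

Neither measured change touches that group, so both guide only loosely. Methoxy in place of hydrogen on an aromatic carbon gave a 1.5-fold higher number from compound 1 to compound 2 (0.18 log units; within the scatter), so a small edit elsewhere left the number in place. Then 5-methylfuran-2-yl in place of 4-methoxyphenyl gave a 260-fold higher number from compound 1 to compound 3 (2.42 log units; beyond the scatter), so exchanging a whole aromatic group can cost a great deal. The new exchange is a smaller edit than that one, and it keeps the fluorine.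

A modest move toward weaker inhibition in this assay is therefore expected, estimated as a 2.8-fold higher number from compound 1 to compound 4 (0.45 log units; beyond the scatter). For compound 4 the estimated value is 150 nM, with an expected range from 40 nM to 1000 nM.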

Compound 4, half-maximal inhibitory concentration: 160 nM
Beside the measured number, compound 4's estimate is 1.1-fold (0.03 log units) below it; the measured number falls inside the stated range.
By their numbers in this assay, from the lowest: compounds 1, 2 and 4 (each within the scatter of the next, the first and the last beyond it); then compound 3.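

In this assay, among these compounds, this is the first change at the place that carries 4-fluorophenyl, on an aromatic carbon ortho to a large group. Moving to 6-fluoropyridin-3-yl keeps the fluorine and the heavy-atom count, exchanges one ring carbon for a nitrogen and adds one counted hydrogen-bond acceptor, and it gives a 3.0-fold higher number from compound 1 to compound 4 (0.48 log units; beyond the scatter) in this single comparison. So this place is not indifferent to the exact make-up of its ring, even though the step is modest and compound 4 stays at 160 nM on the shared core. No measurement at hand ties this step to any particular property of the new ring.

From the compounds shown here alone, whether 6-fluoropyridin-3-yl would give a similar step on the core of compound 2, with its extra methoxy, remains open. Also open is how the number would respond if an amine or a nitrile took the place of the fluorine on this ring, since every compound shown here carries that fluorine.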